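From cyclopentyl to tert-butoxy on a carbonyl carbon

The source may report more compounds than this note shows. Statements on the series, on what has been measured and on what is new or still open speak of the compounds shown alone.

Results so far in a functional assay on HepG2 cells (Homo sapiens) for inhibition, read by scintillation counting, with a stated time of 2 h (on this read-out lower numbers stand for stronger inhibition and higher numbers for weaker inhibition), are these:
- Compound 1 `CC(=O)N1CCC(C(=O)N2CCC(N3CCN(C(=O)c4cc(-c5ccc(C)cc5)nc(-c5ccc6[nH]c(C)c(C)c6c5)c4)CC3)CC2)CC1` gives 294 nM
- Compound 2 `CCNC(=O)Nc1sc2ccccc2c1C(=O)N1CCN(C2CCN(C(C)=O)CC2)CC1` gives "not determined" (no result reported)
- Compound 3 `CCNC(=O)Nc1sc2ccccc2c1C(=O)N1CCN(C2CCN(C(=O)C3CCCC3)CC2)CC1` gives 309 nM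

Compound 3 and compound 1 lie within the scatter of each other, and compound 2 has no number, so compound 3 holds no clear rank in this small set. The next compound is compound 4 `CCNC(=O)Nc1sc2ccccc2c1C(=O)N1CCN(C2CCN(C(=O)OC(C)(C)C)CC2)CC1`, which carries tert-butoxy in place of cyclopentyl on a carbonyl carbon. For the measured compounds named here, no measured pair here differs in one place, so the data do not show how large such a change can be. The starting point is therefore compound 3 at 309 nM alone. In this assay no step beyond the scatter is expected, in either direction. The expected change is a 1.1-fold lower number from compound 3 to compound 4 (0.04 log units; within the scatter), and the uncertainty around it is wide. For compound 4 the estimated value is 280 nM, with an expected range from 90 nM to 850 nM.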

Compound 4, half-maximal inhibitory concentration: 79 nM
For compound 4 the middle estimate is 3.5-fold (0.55 log units) above the measured one, and the stated range ends above it.
By their numbers in this assay, from the lowest: compound 4; then compounds 1 and 3 (each within the scatter of the next).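

In this assay tert-butoxy in place of cyclopentyl on a carbonyl carbon gives a 3.9-fold lower number from compound 3 to compound 4 (0.59 log units; beyond the scatter) and is the first change in this set shown to move the number at all. This position, a carbonyl carbon whose other neighbours are an amide-type nitrogen in a ring, therefore responds to what it carries, even though the group leaving and the group entering both count 5 heavy atoms. Nothing at hand accounts for this step. The compounds shown leave open whether the step follows the oxygen that tert-butoxy brings or the loss of the carbon ring, a question that tert-butyl or cyclopentyloxy on the same carbonyl carbon would address. Compound 2, with its acetyl group, has no reported result and cannot show how a smaller group fares there.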